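A few compounds are considered here, and "the series" means these few. Any claim that something is new, unique, unknown or untested is made for them only; others in the source may bear on it.

Working notes on the thiazole hydrazone series.

Compound 1 is `COc1cc(/C=N/Nc2nc(-c3ccc(Br)cc3)cs2)cc(Br)c1OC`. In an ADME assay on HUVEC cells (Homo sapiens) for inhibition, read by MTT assay, with a stated time of 48 h (a higher number here means a weaker inhibitor, a lower number a stronger inhibitor), compound 1 gives > 100000 nM, which is a limit of the assay and not a number. Compound 2 is `COc1ccccc1-c1csc(N/N=C/c2ccc(F)c(F)c2)n1`; in this assay compound 2 gives > 100000 nM, again a limit rather than a measured value. For the measured compounds named here, both values shown therefore sit at the same boundary, and no ordering between compound 1 and compound 2 can be read from them; the only evidence is the limit of > 100000 nM in this assay, at which 2 of the 2 values shown sit.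

Compound 3 is `COc1ccccc1-c1csc(N/N=C/c2cc(Br)c(OC)c(OC)c2)n1`, not yet tested in this assay. It differs from compound 1 by 2-methoxyphenyl in place of 4-bromophenyl on an aromatic carbon. The group that enters in compound 3 is the same 2-methoxyphenyl that compound 2 already carries on the shared core, and compound 2 sits at the limit; the benzylidene part of compound 3 is that of compound 1, which also sits at the limit. Going by the values given here, no step between measured compounds is available, so the size of the change cannot be calibrated here. The step from compound 1 to compound 3 in this assay is expected to be a step that the limit leaves unreadable from compound 1 to compound 3, that is, none beyond the scatter. Compound 3 is expected to give about 150000 nM, within 50000 nM to 500000 nM, most probably reported as a limit.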

Compound 3, half-maximal inhibitory concentration: > 100000 nM
Compound 3: only a limit was reported; the forecaster's own chance of this, stated with the estimate: 85%; the middle value is on the limit's open side.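

In this assay compound 3 gives > 100000 nM which is a limit of the assay and not a number. For the compounds shown here, no step between compound 1 and compound 3 can therefore be read: the limit of > 100000 nM in this assay, at which 3 of the 3 values shown sit.

The compounds shown leave open how far compound 1, compound 2 and compound 3 each lie past that limit, and whether 2-methoxyphenyl in place of 4-bromophenyl changes the result at all.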